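Two Chlorines Give Way to Two Fluorines

The source may hold more compounds than are shown below. What is called first, only, known or untested is meant among the compounds shown, and "the series" means these compounds.

In a functional assay on PC-3 cells (Homo sapiens) (a higher number here means a weaker inhibitor of growth, a lower number a stronger inhibitor of growth), compound 3 `O=S(=O)(/C=C/c1ccc(Cl)cc1Cl)Cc1ccc(Nc2ncnc3cc(Cl)ccc23)cc1` gives 38000 nM. Compound 2 `O=S(=O)(/C=C/c1ccc(Cl)cc1Cl)Cc1ccc(Nc2ncnc3ccccc23)cc1`, which has hydrogen in place of chloro on an aromatic carbon, gives 19000 nM. The measured step, a 2.0-fold higher number from compound 2 to compound 3 (0.30 log units; within the scatter), leaves these two values level with each other. Compound 1 `O=S(=O)(/C=C/c1ccccc1)Cc1ccc(Nc2ncnc3ccccc23)cc1` gives only a limit, > 100000 nM. Compound 3 therefore sits with compound 2 at the only numbered level so far.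

Compound 4 `O=S(=O)(/C=C/c1ccc(F)cc1F)Cc1ccc(Nc2ncnc3cc(Cl)ccc23)cc1` carries 2,4-difluorophenyl in place of 2,4-dichlorophenyl on a double-bonded chain carbon bound to a double-bonded chain carbon. The closest guide is the change at that same place, where 2,4-dichlorophenyl replaced phenyl: an at least 5.2-fold lower number from compound 1 to compound 2 (0.72 log units; beyond the scatter). Going by the values given here, that step shows that the group there matters in this assay, but no fluorinated compound has been measured. The chloro step on the aromatic carbon was within the scatter and concerns another place, so it offers little guidance. A modest loss of growth inhibition is expected, recovering part of the gap between the phenyl and 2,4-dichlorophenyl compounds. The expected change is a 1.6-fold higher number from compound 3 to compound 4 (0.20 log units; within the scatter). Compound 4 is estimated at 60000 nM, with an expected range from 25000 nM to 130000 nM.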

Compound 4, concentration for 50% growth inhibition: > 100000 nM
Compound 4 gave a limit, no number; the forecaster's own chance of this, stated with the estimate: 30%; middle value at least 1.6-fold (0.22 log units) from the limit.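

In this assay, the swap of halogens gives an at least 2.6-fold higher number from compound 3 to compound 4 (0.42 log units; beyond the scatter), which shows that this position responds to which halogens the ring carries, not merely to the ring carrying two of them. Going by these compounds alone, until now the only change at this place was an at least 5.2-fold lower number from compound 1 to compound 2 (0.72 log units; beyond the scatter), which showed that the group matters but not what it is about 2,4-dichlorophenyl that counts. Compound 4 gives only a limit rather than a number, so the true size of the loss remains unknown, and the step is a minimum for a value that sits at the same ceiling as another compound in the set: the limit of > 100000 nM in this assay, at which 2 of the 4 values shown sit.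

The compounds shown leave open whether both chlorines are needed, since a group with a single chlorine, such as 4-chlorophenyl, does not appear among them, and whether a larger halogen, as in 2,4-dibromophenyl, or a carbon group, as in 2,4-dimethylphenyl, would give stronger growth inhibition than 2,4-dichlorophenyl. They also leave open whether 2,4-difluorophenyl would behave the same way on the core of compound 2, which lacks the added chloro.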